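The source may report more compounds than this note shows. Statements on the series, on what has been measured and on what is new or still open speak of the compounds shown alone.

In an ADME assay on microsomes from liver (Homo sapiens) for metabolic stability, read by LC-MS, with a stated time of 10 min (on this read-out lower numbers stand for a less stable compound and higher numbers for a more stable compound), compound 1 (`CN(C[C@H]1Cc2c(cccc2N2CCNC(C)(C)C2)CN1)[C@H]1CCCc2cccnc21`) gives 100% and compound 2 (`CN(C[C@H]1Cc2c(cccc2N2CCN3CCC[C@H]3C2)CN1)[C@H]1CCCc2cccnc21`) gives 36.6% while compound 3 (`CN(C[C@H]1Cc2c(cccc2N2CCN(Cc3ccccn3)CC2)CN1)[C@H]1CCCc2cccnc21`) gives 4.2% as the lowest of the three numbers, beyond the scatter from both others. Compound 4 (`CN1CCN(c2cccc3c2C[C@H](CN(C)[C@H]2CCCc4cccnc42)NC3)CC1`) is still unmeasured. It differs from compound 3 as follows: hydrogen in place of pyridin-2-yl on a saturated chain carbon bound to an amine nitrogen in a ring. Cut one bond further out, this reads (pyridin-2-yl)methyl to methyl. Among the measured compounds shown here, no measured step makes this change. For the measured compounds named here, the only measured step is a number 63.4 percentage points lower from compound 1 to compound 2 (beyond the scatter) and it is large, so groups on this aromatic carbon can move the number strongly, though that step involves different groups. Compound 3 at 4.2% leaves little room downward. A rise beyond the scatter is therefore expected, with the estimated step being a number 35.8 percentage points higher from compound 3 to compound 4 (beyond the scatter) on this thin evidence. For compound 4 the estimated value is 40% within an expected range of 15% to 75% in this read-out.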

Compound 4, percent of the compound remaining: 75.8%
For compound 4 the middle estimate is 35.8 percentage points below the measured one; measured number above the stated range.
By their numbers in this assay, from the lowest: compound 3; then compound 2; then compound 4; then compound 1.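

In this assay, cutting (pyridin-2-yl)methyl back to methyl gives a number 71.6 percentage points higher from compound 3 to compound 4 (beyond the scatter) and shows that the group on this piperazine nitrogen, not only the group's attachment to the aromatic carbon, can move the number strongly. With 4-methylpiperazin-1-yl on the aromatic carbon, the series reads a number 39.2 percentage points higher from compound 2 to compound 4 (beyond the scatter) and a number 24.2 percentage points lower from compound 1 to compound 4 (beyond the scatter) so this group places compound 4 inside the range set by the other compounds. Fewer heavy atoms in the group do not simply go with a higher number, and compound 1 goes against that pattern: its group is larger than that of compound 4, yet it stands higher.

Open, as far as these compounds go, is whether ethyl or benzyl in place of methyl would stay near compound 4 or fall toward compound 3. Nothing shown gives a reason for any of these steps.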